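The source may report more compounds than this note shows. Statements on the series, on what has been measured and on what is new or still open speak of the compounds shown alone.

Measured in a functional assay on COLO 205 cells (Homo sapiens) for inhibition, read by sulforhodamine B assay, with a stated time of 48 h, tested at 50 uM; on this read-out higher numbers stand for more inhibition of growth at the one concentration tested and lower numbers for less inhibition of growth:
Compound 1 `COc1cc(/C=C/C(=O)/C=C/c2cccc3ccccc23)ccc1OCc1cn(CCCOc2cc(=O)oc3ccccc23)nn1`: 64%
Compound 2 `COc1cc(/C=C/C(=O)/C=C/c2cccs2)ccc1OCc1cn(CCCCCOc2cc(=O)oc3ccccc23)nn1`: 30%

Compound 1 has the higher of the two numbers, and its gap to compound 2 is beyond the usual scatter. These two compounds differ in more than one place, so the gap cannot be tied to any single change. Compound 3 `COc1cc(/C=C/C(=O)/C=C/c2ccccc2)ccc1OCc1cn(CCCOc2cc(=O)oc3ccccc23)nn1` keeps the rest of compound 1 and changes one group: phenyl in place of naphthalen-1-yl on a double-bonded chain carbon bound to a double-bonded chain carbon. For the measured compounds named here, no measured pair isolates this swap, so any expectation is loose. Compound 2, which carries neither group, gives 30%, and this weakly favours a fall over a rise. The estimated a number 14 percentage points lower from compound 1 to compound 3 (beyond the scatter) in this assay is expected to be a moderate fall, slightly beyond the scatter. Compound 3 is estimated at 50%, with an expected range of 30% to 70%.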

Compound 3, percent growth inhibition at one concentration: 43%
The estimate for compound 3 lay 7 percentage points above the measured number; low and high end bracket the measured number.
By their numbers in this assay, from the lowest: compound 2; then compound 3; then compound 1.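

For the compounds shown here, compound 1 and compound 3 form the first pair here that differs in one place only, so this gap can be tied to a single swap. In this assay, replacing naphthalen-1-yl with phenyl on a double-bonded chain carbon bound to a double-bonded chain carbon gives a number 21 percentage points lower from compound 1 to compound 3 (beyond the scatter) and removes one of the two six-membered aromatic rings from this group. The group at this position therefore affects growth inhibition, and the larger of these two groups gives the higher number, although nothing available explains why.

The compounds shown leave open how a phenyl ring carrying a chlorine atom or a dimethylamino group would behave at this position. They also leave open whether the same swap would give a similar step with a different chain on the shared core.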